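Carbamate in Place of a Prenyl Ether on a Shared Core

The source may report more compounds than this note shows. Statements on the series, on what has been measured and on what is new or still open speak of the compounds shown alone.

Measured compounds:
compound 1, `CC(C)=CCOc1cc(=O)n(CCCO)c2c1CC(CC=C(C)C)C(C)(C)C2`: 7.5%
compound 2, `CC(C)=CCC1Cc2c(OCCCNS(=O)(=O)c3ccc([N+](=O)[O-])cc3)cc(=O)n(CCCO)c2CC1(C)C`: 17.3%

In a functional assay on PANC-1 cells (Homo sapiens) for inhibition, read by MTT assay, with a stated time of 24 h, tested at 10 uM (a lower number here means less inhibition, a higher number more inhibition at the concentration tested (going by the name of the read-out)), compound 1 gives 7.5%. Compound 2 gives 17.3% in this assay, and the two numbers lie within the usual scatter of each other, so compound 1 cannot be told apart from compound 2 on these figures alone.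

Compound 3, `CC(C)=CCC1Cc2c(OC(=O)Nc3ccccc3F)cc(=O)n(CCCO)c2CC1(C)C`, has not yet been measured in this assay. It differs from compound 1 in one place: (2-fluorophenyl)carbamoyl in place of 3-methylbut-2-en-1-yl on an oxygen on an aromatic ring. Among the measured compounds shown here, no step between two measured compounds is known that would show what such a change does here, and the one other measured compound, compound 2, gives a number within the scatter of compound 1. The step from compound 1 to compound 3 is therefore expected to be small, a number 6.5 percentage points higher from compound 1 to compound 3 (within the scatter), with no clear direction beyond the scatter. Compound 3 is expected to give about 14% in this assay, within a range from 0% to 35%.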

Compound 3, a percentage reported as inhibition, at one concentration (the size of the read-out at that concentration, not a potency): 0%
Compound 3: middle estimate off by 14 percentage points, on the high side; the measured number falls inside the stated range.
By their numbers in this assay, from the lowest: compounds 3, 1 and 2 (each within the scatter of the next, the first and the last beyond it).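

In this assay, among the compounds shown here, (2-fluorophenyl)carbamoyl in place of 3-methylbut-2-en-1-yl on an oxygen on an aromatic ring gives the first step that can be read at this position, a number 7.5 percentage points lower from compound 1 to compound 3 (within the scatter), and so it stays within the scatter. This position therefore carries the entering group, with its 10 heavy atoms, its aromatic ring and its hydrogen-bond donor, without a reading that stands apart from that of the smaller prenyl ether of compound 1. Nothing measured here bears on why the step has this size.

The compounds shown leave open whether the fluorine matters, as a plain phenylcarbamoyl group on the same oxygen would tell. They also leave open whether a benzyl ether or a chain ending in a dimethylamino group at this position would give a step beyond the scatter.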